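Oxygen for Sulfur on the Amine Nitrogen of Compound 3

The compounds below may be only part of what the source reports. "The series", "measured", "known", "first", "only" and "open" are said of these compounds alone.

Compound 3 `CCNC(=S)NC1CC(C)(C)Oc2ccc(Cl)cc21` gives 96000 nM in a functional assay on U-373MG ATCC cells (Homo sapiens) for inhibition, read by MTT assay, with a stated time of 72 h; on this read-out lower numbers stand for stronger inhibition and higher numbers for weaker inhibition. Among the three compounds measured, it carries the highest number, yet compound 1 `CC1(C)CC(NC(=O)Nc2ccccc2)c2cc(Cl)ccc2O1` with 68000 nM and compound 2 `CC(C)NC(=S)NC1CC(C)(C)Oc2ccc(Cl)cc21` with 57000 nM both lie within the scatter of it, so no order among them can be read. Within the data shown here, the only measured step, a 1.7-fold higher number from compound 2 to compound 3 (0.23 log units; within the scatter), concerns the chain on the nitrogen, not the change now made. Compound 4 `CCNC(=O)NC1CC(C)(C)Oc2ccc(Cl)cc21` differs from compound 3 by a group of 5 heavy atoms (3 carbon, 1 nitrogen, 1 oxygen; no ring) in place of a group of 5 heavy atoms (3 carbon, 1 nitrogen, 1 sulfur; no ring), on an amine nitrogen; sulfur gives way to oxygen, forming ethylcarbamoyl. Among the measured compounds shown here, no measured pair shows this exchange, so a shift no larger than the scatter is expected: a 1.1-fold lower number from compound 3 to compound 4 (0.03 log units; within the scatter). Compound 4 is therefore estimated at 90000 nM, within 40000 nM to 200000 nM.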

Compound 4, half-maximal inhibitory concentration: > 100000 nM
Compound 4 ended at the assay's limit (the forecaster's own chance of this, stated with the estimate: 15%); middle value at least 1.1-fold (0.04 log units) from the limit.
By their numbers in this assay, from the lowest: compounds 2, 1 and 3 (each within the scatter of the next). At a limit, above all of these: compound 4.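

In this assay compound 4 gives > 100000 nM, a limit of the assay and not a number. Oxygen for sulfur on this amine nitrogen therefore brought no measurable strengthening: the comparisons give an at least 1.0-fold higher number from compound 3 to compound 4 (0.01 log units; that floor lies within the scatter), an at least 1.7-fold higher number from compound 2 to compound 4 (0.24 log units; that floor lies within the scatter) and an at least 1.4-fold higher number from compound 1 to compound 4 (0.16 log units; that floor lies within the scatter), and these are only floors, so the true size of each step stays unknown. The reading is bounded by the assay itself: the limit of > 100000 nM in this assay, at which 1 of the 4 values shown sits.

Open, as far as these compounds go, is how far compound 4 truly lies from the others. Also open, from the compounds shown here alone, is whether a longer chain or a cyclohexyl group on the thiourea nitrogen would lower the number beyond the scatter.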